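The compounds below may be only part of what the source reports. "The series", "measured", "known", "first", "only" and "open" are said of these compounds alone.

Measured so far:
compound 1 `O=S(=O)(/C=C/c1ccc(O)c(O)c1)NCc1ccc(Cl)cc1`: 13700 nM
compound 2 `O=S(=O)(/C=C/c1ccc(O)c(O)c1)NCc1ccc(F)cc1`: 18900 nM

In a functional assay on BV-2 cells (Mus musculus) for inhibition, read by Griess assay, with stated times of 3 h and 24 h (a higher number here means a weaker inhibitor, a lower number a stronger inhibitor), compound 1 gives 13700 nM. In this assay compound 2 gives 18900 nM. Among the measured compounds shown here, the two numbers sit within the scatter of each other; the single computed step between them is a 1.4-fold higher number from compound 1 to compound 2 (0.14 log units; within the scatter), a fluoro in place of chloro on an aromatic carbon. Compound 2 thus has one neighbour on record, compound 1, and no separation from it beyond the scatter.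

Compound 3 `Cc1ccc(CNS(=O)(=O)/C=C/c2ccc(O)c(O)c2)cc1` differs from compound 2 in one place: methyl in place of fluoro on an aromatic carbon. For the measured compounds named here, no measured step exchanges a halogen for a methyl, so only the chloro-to-fluoro step bears on this change, and it was within the scatter. On that basis the expectation for compound 3 in this assay is a number close to that of compound 2, with a step of a 1.3-fold lower number from compound 2 to compound 3 (0.10 log units; within the scatter) that is not expected to pass beyond the scatter in either direction. The estimate for compound 3 is 15000 nM, with an expected range from 7000 nM to 35000 nM.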

Compound 3, half-maximal inhibitory concentration: 43900 nM
For compound 3 the middle estimate is 2.9-fold (0.47 log units) below the measured one; the measured number lies above the stated range.
By their numbers in this assay, from the lowest: compounds 1 and 2 (each within the scatter of the next); then compound 3.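

In this assay, the chloro-to-fluoro exchange gave no separation, but this position, para to a large group, does respond to a change of substituent: methyl in place of fluoro gives a 2.3-fold higher number from compound 2 to compound 3 (0.37 log units; beyond the scatter), and methyl in place of chloro gives a 3.2-fold higher number from compound 1 to compound 3 (0.51 log units; beyond the scatter). Both steps are modest, but both lie beyond the scatter, so the 4-methylphenyl compound 3 is the weakest inhibitor of the three, while compound 1 and compound 2 remain within the scatter of each other. No measurement at hand gives a cause for this difference between methyl and the two halogens.

The three compounds cannot show whether the weaker result is particular to methyl or would also appear with a longer chain such as ethyl, or with methoxy, trifluoromethyl, an amine or a carboxylic acid at the same place. They also leave open how the parent compound with only hydrogen at this place would compare, and so whether the halogens or the methyl depart from it.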